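Working notes on the amine variation at the shared core

The compounds below may be only part of what the source reports. "The series", "measured", "known", "first", "only" and "open" are said of these compounds alone.

Compound 1 `COc1cc(/C=C/c2nc(N(C)C)c3sccc3n2)cc(OC)c1OC`: in a functional assay on L02 cells (Homo sapiens) for inhibition, read by Griess assay, with stated times of 1 h and 24 h (a higher number here means a weaker inhibitor, a lower number a stronger inhibitor), compound 1 gives > 1000000 nM, which is a limit of the assay and not a number.
Compound 2 `CCN1CCN(c2nc(/C=C/c3cc(OC)c(OC)c(OC)c3)nc3ccsc23)CC1`: in this assay compound 2 gives > 1000000 nM, again a limit.
Compound 3 `COc1cc(/C=C/c2nc(NCc3ccc(Cl)cc3)c3sccc3n2)cc(OC)c1OC`: in this assay compound 3 gives > 1000000 nM, also a limit.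

Compound 3 therefore stands at the limit of the assay, and so do the other two measured compounds (the limit of > 1000000 nM in this assay, at which 3 of the 3 values shown sit). The steps among them, a step that the two limits leave unreadable from compound 1 to compound 2, a step that the two limits leave unreadable from compound 1 to compound 3 and a step that the two limits leave unreadable from compound 2 to compound 3, cannot be read in size or direction; both ends of each are limits. What can be said is that three different substituents on the aromatic nitrogen all left the series at the limit in this assay.

Compound 4 `COc1cc(/C=C/c2nc(NCc3ccco3)c3sccc3n2)cc(OC)c1OC` differs from compound 3 by furan-2-yl in place of 4-chlorophenyl on a saturated chain carbon bound to a nitrogen on an aromatic ring. For the measured compounds named here, no measured step bears on this change; the measured steps all concern the substituent on the aromatic nitrogen, and none of them gave a readable number. With nothing in the series moving off the limit, the step from compound 3 to compound 4 is expected to be a number no higher from compound 3 to compound 4 (the limit leaves the size open) in this assay, that is, no readable change. Compound 4 is accordingly estimated at 1000000 nM, with a range from 300000 nM to 3000000 nM, and the assay is expected most likely to report only its limit again.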

Compound 4, half-maximal inhibitory concentration: 189000 nM
Compound 4: the middle estimate sits 5.3-fold (0.72 log units) above what was measured; measured number outside the range, below it.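

Furan-2-yl in place of 4-chlorophenyl gives the first readable number of the series in this assay, with an at least 5.2-fold lower number from compound 3 to compound 4 (0.72 log units; beyond the scatter). The substituent on a saturated chain carbon bound to a nitrogen on an aromatic ring can therefore take the series off the limit, and the same holds when ((furan-2-yl)methyl)amino is set against the other two amines, with an at least 5.2-fold lower number from compound 2 to compound 4 (0.72 log units; beyond the scatter) and with an at least 5.2-fold lower number from compound 1 to compound 4 (0.72 log units; beyond the scatter). All three steps give only a minimum size, the steps among compound 1, compound 2 and compound 3 remain unreadable, and compound 4 is the only compound with a number: the limit of > 1000000 nM in this assay, at which 3 of the 4 values shown sit.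

With one readable compound, the data do not separate the five-membered aromatic ring from its oxygen hetero atom, nor the gain of furan-2-yl from the loss of 4-chlorophenyl. As far as these compounds go, whether thiophen-2-yl or unsubstituted phenyl on the same chain carbon, or a longer chain such as 2-(furan-2-yl)ethyl on the nitrogen, would also leave the limit stays open.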